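This account rests on a few compounds, and the source may have more. Where it says the series, first, only, none or still open, it means among the compounds named here.

Compound 1 `COc1cc(OC)c(/C=C/S(=O)(=O)Cc2ccc(OC)c(OP(=O)(O)O)c2)c(OC)c1` was examined in a functional assay on BT-20 cells (Homo sapiens) for antiproliferative activity, read by trypan blue exclusion (on this read-out lower numbers stand for stronger inhibition and higher numbers for weaker inhibition), where compound 1 gives 5 nM. This is the only numeric value among the results shown; the other entry is a limit rather than a number. Compound 2 `COc1ccc(CS(=O)(=O)/C=C/c2ccc(OC)c(OC)c2OC)cc1`, a differently substituted analogue, reaches only a limit in this assay, recorded for compound 2 as > 20000 nM. That entry for compound 2 corresponds to the limit of > 20000 nM in this assay, at which 1 of the 2 values shown sits. Compound 3 `COc1ccc(CS(=O)(=O)/C=C/c2c(OC)cc(OC)cc2OC)cc1` is the analogue of compound 1 in which the change is a hydrogen atom in place of a group of 5 heavy atoms (4 oxygen, 1 phosphorus; no ring), on an aromatic carbon. For the measured compounds named here, no measured pair of compounds differs in a single place, so the size of this step has to be anticipated rather than read from the data. The author expects the step to be a loss of potency clearly beyond the usual scatter, a 200-fold higher number from compound 1 to compound 3 (2.30 log units; beyond the scatter). The author's estimate for compound 3 in this assay is 1000 nM, with a range from 100 nM to 20000 nM.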

Compound 3, half-maximal inhibitory concentration: 20 nM
Beside the measured number, compound 3's estimate is 50-fold (1.70 log units) above it, outside the stated range (below it).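

In this assay the exchange of the group of 5 heavy atoms (4 oxygen, 1 phosphorus) for hydrogen gives a 4.0-fold higher number from compound 1 to compound 3 (0.60 log units; beyond the scatter) and so counts as a modest loss, though one beyond the usual scatter. This shows that the aromatic carbon ortho to a methoxy group does not need that group for compound 3 to remain strongly active, a point that compound 1 alone could not show. Nothing among the results shown accounts for the size of this step.

The compounds shown leave open how a hydroxyl, an amine or a carboxylic acid on this same aromatic carbon would compare with hydrogen and with the group in compound 1. They also leave open whether this modest step would hold on another methoxy arrangement of the shared core.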